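Amino-amide in place of the carboxypropyl chain

The source may hold more compounds than are shown below. What is called first, only, known or untested is meant among the compounds shown, and "the series" means these compounds.

Measured compounds:
Compound 1, `CCOc1ccccc1-c1ccc(-c2nc3cnccc3c(C[C@H](C)C(=O)O)c2C#N)cc1`: 2.2
Compound 2, `CC[C@@H](Nc1c(C#N)c(-c2ccc(-c3cccc(CO)c3)cc2)nc2cnccc12)C(N)=O`: 2

In a physicochemical assay for lipophilicity, read by HPLC, at pH 7.5 (on this read-out lower numbers stand for lower lipophilicity and higher numbers for higher lipophilicity), compound 1 gives 2.2, the higher of the two numbers, and compound 2 gives 2, which lies within the scatter of that value. Within the data shown here, no step between compounds differing in one place has been measured, so nothing here fixes the size of any change.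

Compound 3, `CCOc1ccccc1-c1ccc(-c2nc3cnccc3c(N[C@H](CC)C(=O)N(C)C)c2C#N)cc1`, is not yet measured. It differs from compound 1 in one place: (1-(dimethylcarbamoyl)propyl)amino in place of 2-carboxypropyl on an aromatic carbon. The entering group resembles the chain found in compound 2, which gives 2, but compound 2 differs from compound 3 in more than that one place, so it offers only a loose guide.

The step of a number 1.00 log units higher from compound 1 to compound 3 (beyond the scatter) is expected to go upward, beyond the scatter. Compound 3 is estimated at 3.2, in the range 2.6 to 3.8.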

Compound 3, distribution coefficient: 3.7
Compound 3: middle estimate off by 0.50 log units, on the low side; the range from low to high includes it.
By their numbers in this assay, from the lowest: compounds 2 and 1 (each within the scatter of the next); then compound 3.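

In this assay, (1-(dimethylcarbamoyl)propyl)amino in place of 2-carboxypropyl gives a number 1.50 log units higher from compound 1 to compound 3 (beyond the scatter). This single-place comparison shows that the read-out at this aromatic carbon, ortho to a cyano group and opposite the ring nitrogen, responds strongly to this exchange of chains on an otherwise unchanged structure, which the earlier pair, differing in more than one place, could not show. Nothing shown accounts for the size of this step.

The exchange alters the link to the core and the end of the chain together, so the compounds shown leave open how much of the step belongs to each. An amino-linked chain ending in a carboxylic acid, or a carbon-linked chain ending in dimethylcarbamoyl, would bear on that question.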